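Sulfonyl Substituent Exchange and Expected Metabolic Stability

This account rests on a few compounds, and the source may have more. Where it says the series, first, only, none or still open, it means among the compounds named here.

Three compounds built on a shared core have been examined in an ADME assay on microsomes from liver (Homo sapiens) for metabolic stability, with a stated time of 10 min; on this read-out higher numbers stand for a more stable compound and lower numbers for a less stable compound. Compound 1 `CC(C)S(=O)(=O)NC(=O)c1ccc(Nc2nc(NC3(c4ccc(Cl)cc4)CC3)nc(OCC(F)(F)F)n2)cc1` gives 100% in this assay. Compound 2 `CC(=O)NCCS(=O)(=O)NC(=O)c1ccc(Nc2nc(NC3(c4ccc(Cl)cc4)CC3)nc(OCC(F)(F)F)n2)cc1` gives 95%, and compound 3 `COC(=O)NCCS(=O)(=O)NC(=O)c1ccc(Nc2nc(NC3(c4ccc(Cl)cc4)CC3)nc(OCC(F)(F)F)n2)cc1` gives 90%. On these numbers compound 3 stands within the usual scatter of both companions: a number 5 percentage points lower from compound 2 to compound 3 (within the scatter), and a number 10 percentage points lower from compound 1 to compound 3 (within the scatter). The remaining pair behaves the same way, as a number 5 percentage points lower from compound 1 to compound 2 (within the scatter).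

Compound 4 `CN(C)S(=O)(=O)NC(=O)c1ccc(Nc2nc(NC3(c4ccc(Cl)cc4)CC3)nc(OCC(F)(F)F)n2)cc1` is not yet measured. It differs from compound 3 by dimethylamino in place of 2-((methoxycarbonyl)amino)ethyl on a sulfonyl sulfur. Among the measured compounds shown here, the steps that bear on this change are the two that already exchanged the group on the sulfonyl sulfur, from compound 1 to compound 2 and from compound 1 to compound 3, and neither moved the read-out beyond the scatter. Compound 4 is therefore expected to show a number 2 percentage points higher from compound 3 to compound 4 (within the scatter), that is, no step beyond the scatter. Compound 4 is estimated to give 92%, with a range from 75% to 100%.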

Compound 4, percent of the compound remaining: 86%
Estimate against measurement, compound 4: 6 percentage points above, and the stated range covers the measured number.
By their numbers in this assay, from the lowest: compounds 4, 3, 2 and 1 (each within the scatter of the next, the first and the last beyond it).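

In this assay, among the compounds shown here, dimethylamino on a sulfonyl sulfur gives the only step at this position that lies beyond the scatter, a number 14 percentage points lower from compound 1 to compound 4 (beyond the scatter), whereas the two exchanges of isopropyl for the longer chains did not. The same group stays within the scatter of both chains, a number 9 percentage points lower from compound 2 to compound 4 (within the scatter) and a number 4 percentage points lower from compound 3 to compound 4 (within the scatter), so the measurements separate it only from isopropyl and give no clear order among compound 2, compound 3 and compound 4. Nothing available here accounts for this modest step.

The compounds shown leave open whether the step goes with the nitrogen on the sulfonyl sulfur or with dimethylamino as a whole. Methylamino or diethylamino at this place, or a tert-butyl group as an all-carbon comparison, would help tell these readings apart.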